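The compounds below may be only part of what the source reports. "The series", "measured", "known", "first", "only" and "open" are said of these compounds alone.

Going by the values given here, in a functional assay on BT-549 cells (Homo sapiens) for inhibition, read by sulforhodamine B assay, with a stated time of 48 h (a higher number here means a weaker inhibitor of growth, a lower number a stronger inhibitor of growth), two compounds with closely related structures have numbers so far. Compound 1 `O=C(Nc1cccc(-n2cc(-c3ccncc3)c(-c3ccc(Cl)c(O)c3)n2)c1)Nc1cccc(C(F)(F)F)c1` gives 21400 nM, while compound 2 `COc1cc(-c2nn(-c3cccc(NC(=O)c4cccc(C(F)(F)F)c4)c3)cc2-c2ccncc2)ccc1Cl` gives 46800 nM. Compound 2 therefore holds the higher of the two numbers, which makes it the weaker inhibitor of growth by a gap beyond the usual scatter.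

Compound 3 `COc1cc(-c2nn(-c3cccc(NC(=O)Nc4ccc(Cl)c(C(F)(F)F)c4)c3)cc2-c2ccncc2)ccc1Cl` has not yet been measured. It differs from compound 2 in one place, with (4-chloro-3-(trifluoromethyl)phenyl)amino in place of 3-(trifluoromethyl)phenyl on a carbonyl carbon. Compound 1 also has an amino group on that carbonyl carbon and gives 21400 nM, but it differs from compound 3 elsewhere too, so it is only a loose guide. A moderate fall in the number is expected, an estimated step of a 2.8-fold lower number from compound 2 to compound 3 (0.44 log units; beyond the scatter). The estimate for compound 3 is 17000 nM, with an expected range of 5000 nM to 50000 nM.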

Compound 3, concentration for total growth inhibition: 10200 nM
Estimate against measurement, compound 3: 1.7-fold (0.22 log units) above, and the stated range covers the measured number.
By their numbers in this assay, from the lowest: compound 3; then compound 1; then compound 2.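

Going by these compounds alone, this is the first pair that differs in only one place, so the change on the carbonyl carbon can be read on its own: in this assay, putting (4-chloro-3-(trifluoromethyl)phenyl)amino in place of 3-(trifluoromethyl)phenyl gives a 4.6-fold lower number from compound 2 to compound 3 (0.66 log units; beyond the scatter), a modest gain in growth inhibition. The swap alters two things at once, adding an amino nitrogen with its hydrogen-bond donor and adding a chlorine, and this single step cannot divide the gain between them. No measurement shown explains the fall in the number.

The compounds shown leave open whether the amino nitrogen or the chlorine carries the gain on this core. Going by these compounds, how a (4-fluoro-3-(trifluoromethyl)phenyl)amino group or a morpholine on the same carbonyl carbon would read also remains open.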